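Shared-core series: ether side chain and amine chain length

The source may report more compounds than this note shows. Statements on the series, on what has been measured and on what is new or still open speak of the compounds shown alone.

In a functional assay on HepG2 cells (Homo sapiens) for cytotoxicity, read by MTT assay, with a stated time of 48 h (on this read-out higher numbers stand for weaker inhibition and lower numbers for stronger inhibition), compound 1 `CN(C)CCNc1ccnc2cc(OCc3ccccc3)ccc12` gives 3120 nM.
In this assay compound 2 `C=CCOc1ccc2c(NCCN(C)C)ccnc2c1` gives 1660 nM.
In this assay compound 3 `CCCCCCOc1ccc2c(NCCN(C)C)ccnc2c1` gives 1370 nM.

Compound 2 holds the second highest of the three numbers; its nearest neighbour is compound 3, a 1.2-fold lower number from compound 2 to compound 3 (0.08 log units; within the scatter), and the furthest is compound 1, a 1.9-fold lower number from compound 1 to compound 2 (0.27 log units; within the scatter), both within the scatter. Compound 4 `C=CCOc1ccc2c(NCCCN(C)C)ccnc2c1` differs from compound 2 by (dimethylamino)methyl in place of dimethylamino on a saturated chain carbon, two bonds along the chain from a nitrogen on an aromatic ring. Every measured step, a 1.9-fold lower number from compound 1 to compound 2 (0.27 log units; within the scatter), a 2.3-fold lower number from compound 1 to compound 3 (0.36 log units; beyond the scatter) and a 1.2-fold lower number from compound 2 to compound 3 (0.08 log units; within the scatter), changes only the group on the saturated chain carbon bound to the ring oxygen; none touches the amine chain, so none bears directly on this change. Within the data shown here, with no precedent, no step beyond the scatter is expected for compound 4 in this assay: a 1.0-fold higher number from compound 2 to compound 4 (0.01 log units; within the scatter). Compound 4 is therefore estimated at 1700 nM, with a range from 700 nM to 4200 nM.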

Compound 4, half-maximal inhibitory concentration: 3990 nM
Compound 4: middle estimate off by 2.3-fold (0.37 log units), on the low side, and the stated range covers the measured number.
By their numbers in this assay, from the lowest: compounds 3, 2, 1 and 4 (each within the scatter of the next, the first and the last beyond it).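

Among these compounds, the move from (2-(dimethylamino)ethyl)amino to (3-(dimethylamino)propyl)amino is the first change to the amine chain, and in this assay it gives a 2.4-fold higher number from compound 2 to compound 4 (0.38 log units; beyond the scatter), a modest step beyond the scatter. The amine chain is therefore not silent on this read-out, and its length matters here at least as much as the ether side chain changes seen so far. Nothing available explains this step.

On these data alone, it remains open whether a longer chain ending in dimethylamino would continue this direction, and whether a piperidine in place of dimethylamino would keep the number of compound 2. Also open, as far as these compounds go, is whether the same lengthening gives a similar step with the phenyl and pentyl ether side chains of compound 1 and compound 3.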